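Swapping the Aryl Group on a Urea: Expected Thermal Shift

The compounds below may be only part of what the source reports. "The series", "measured", "known", "first", "only" and "open" are said of these compounds alone.

Compound 1 `CC(C)(C)c1cc(NC(=O)Nc2cc(C(F)(F)F)cc(C(F)(F)F)c2)n(-c2ccccc2)n1` gives 0.8 degrees C in an assay on isolated protein for inhibition of Ephrin type-A receptor 2 (Homo sapiens), read by thermal shift assay, tested at 10 uM; a higher number here means that the compound stabilises the target more against heat, a lower number that the compound stabilises the target less.
Compound 2 `Cc1cc(C)cc(NC(=O)Nc2cc(C(C)(C)C)nn2-c2ccccc2)c1` gives 0.7 degrees C in this assay.

Both compounds share the same core, a urea bridging a phenyl-bearing pyrazole to a second aromatic ring, and both produce only a small stabilisation of the target against heat. The value of compound 2 and the value of compound 1 lie within the usual scatter of each other, so the two cannot be told apart by these measurements; neither stands out.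

Compound 3 `COc1cccc(NC(=O)Nc2cc(C(C)(C)C)nn2-c2ccccc2)c1` has not been measured yet. It differs from compound 2 at one spot: 3-methoxyphenyl in place of 3,5-dimethylphenyl on an amide-type nitrogen. Going by the values given here, no pair of measured compounds with a single change of this kind is available, so there is nothing in the data to say whether this swap moves the number up or down. The expectation is therefore a step from compound 2 to compound 3 of no change at the digits printed from compound 2 to compound 3 (within the scatter) in this assay, that is, none beyond the scatter. Compound 3 is estimated at 0.7 degrees C in this assay, with a range from -0.4 degrees C to 1.8 degrees C.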

Compound 3, shift of the target's melting temperature: 1.8 degrees C
For compound 3 the middle estimate is 1.1 degrees C below the measured one; the measured number falls inside the stated range.
By their numbers in this assay, from the lowest: compounds 2, 1 and 3 (each within the scatter of the next, the first and the last beyond it).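

Going by these compounds alone, putting 3-methoxyphenyl in place of 3,5-dimethylphenyl on an amide-type nitrogen gives a number 1.1 degrees C higher from compound 2 to compound 3 (beyond the scatter) in this assay, the first step large enough to stand clear of the scatter. The position is therefore not silent: the aryl group on this nitrogen can change how much the compound stabilises the target, even though the step itself is modest and rests on a single pair. The two groups have the same number of heavy atoms and the same kind of ring, with the entering group adding an oxygen and a hydrogen-bond acceptor to the count, but nothing at hand shows which feature of the swap produced the step.

The swap changes two things at once, replacing two methyl groups with one methoxy group, so this one pair cannot separate the effect of removing a methyl group from that of introducing the oxygen. Plain phenyl, an ethoxy group with its longer chain, or an amine on the same ring would be the kinds of group needed to show which of these matters and how far the number can move at this position.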